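A few compounds are considered here, and "the series" means these few. Any claim that something is new, unique, unknown or untested is made for them only; others in the source may bear on it.

In a functional assay on HepG2 cells (Homo sapiens) for antiproliferative activity, read by MTT assay, with a stated time of 48 h (on this read-out lower numbers stand for stronger inhibition and higher numbers for weaker inhibition), compound 1 (`C#CC(C)OC(=O)c1ccc(C(CC)(CC)c2ccc(OCCC(O)(CC)CC)c(C)c2)n1CC`) gives > 50000 nM as a limit, not a number. Compound 2 (`C#CCCOC(=O)c1ccc(C(CC)(CC)c2ccc(OCCC(O)(CC)CC)c(C)c2)n1CC`) gives > 50000 nM as a limit too, and so stands at the limit of > 50000 nM in this assay, at which 2 of the 2 values shown sit, with no number of its own. Going by the values given here, the one measured step (a step that the two limits leave unreadable from compound 1 to compound 2) therefore has no size to carry forward. Compound 3 (`CCOc1ccc(NC(=O)c2ccc(C(CC)(CC)c3ccc(OCCC(O)(CC)CC)c(C)c3)n2CC)cc1`) brings a new change ((4-ethoxyphenyl)amino in place of (but-3-yn-1-yl)oxy on a carbonyl carbon): (4-ethoxyphenyl)amino in place of (but-3-yn-1-yl)oxy on a carbonyl carbon. With no readable step behind it, any gain in this assay is a cautious guess, and the expected step (an at least 1.6-fold lower number from compound 2 to compound 3 (0.22 log units; that floor lies within the scatter)) is only an estimate, leaning toward stronger inhibition. For compound 3 the estimated value is 30000 nM (expected range 6000 nM to 50000 nM) and it may again prove only a limit.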

Compound 3, half-maximal inhibitory concentration: > 50000 nM
Compound 3 ended at the assay's limit; the forecaster's own chance of this, stated with the estimate: 55%; at least 1.6-fold (0.22 log units) between middle value and limit.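

The steps among compound 1, compound 2 and compound 3 cannot be read, because all three stop at one shared limit: the limit of > 50000 nM in this assay, at which 3 of the 3 values shown sit. The compounds shown leave open which group on the carbonyl carbon, if any, gives a measurable value.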